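Trading an amino link for an ether link

The compounds below may be only part of what the source reports. "The series", "measured", "known", "first", "only" and "open" are said of these compounds alone.

In an ADME assay on the whole organism (plasma) with Rattus norvegicus as the target, at a dose of 1 mg/kg by the oral route (on this read-out higher numbers stand for higher exposure at the dose given and lower numbers for lower exposure), compound 1 `CCCCN(CC)c1nc(C)nc2c1nnn2-c1ccc(C(C)C)cc1Br` gives 203 ng.h/mL and compound 2 `CCC(COC)Nc1nc(C)nc2c1nnn2-c1ccc(C(C)C)cc1Br` gives 63.3 ng.h/mL as the lower of the two numbers. Compound 3 `CCC(COC)Oc1nc(C)nc2c1nnn2-c1ccc(C(C)C)cc1Br` differs from compound 2 in one group (1-(methoxymethyl)propoxy in place of (1-(methoxymethyl)propyl)amino on an aromatic carbon) with 1-(methoxymethyl)propoxy in place of (1-(methoxymethyl)propyl)amino on an aromatic carbon. Going by the values given here, the only measured step on that carbon is a 3.2-fold lower number from compound 1 to compound 2 (0.51 log units; beyond the scatter) and it involves a different pair of groups, so it is only a loose guide. A small rise is expected, with a 1.6-fold higher number from compound 2 to compound 3 (0.20 log units; within the scatter) as the estimated step and no firm direction. In this assay the estimate for compound 3 is 100 ng.h/mL with a range from 33 ng.h/mL to 300 ng.h/mL as its expected span.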

Compound 3, area under the concentration-time curve: 9.12 ng.h/mL
Compound 3: middle estimate off by 11-fold (1.04 log units), on the high side; measured number outside the range, below it.
By their numbers in this assay, from the lowest: compound 3; then compound 2; then compound 1.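

In this assay, the atom linking the side chain to the core matters: with the chain otherwise unchanged, putting oxygen in place of the amino nitrogen, which also removes the hydrogen-bond donor, gives a 6.9-fold lower number from compound 2 to compound 3 (0.84 log units; beyond the scatter) on this aromatic carbon. Replacing butyl(ethyl)amino with 1-(methoxymethyl)propoxy gives a 22-fold lower number from compound 1 to compound 3 (1.35 log units; beyond the scatter) and leaves the ether with the lowest exposure of the three. Nothing available explains this drop.

Only one matched amino and ether pair is shown, so the size of this drop with other side chains remains open. Equally open, from the compounds shown here alone, is how a sulfur link or a simple methoxy group would behave here.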